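Replacing 4-nitrophenyl with 2-phenylethenyl in compound 3

The source may report more compounds than this note shows. Statements on the series, on what has been measured and on what is new or still open speak of the compounds shown alone.

compound 1 `C(=N/c1sc2c(c1-c1nc3ccccc3s1)CCCC2)\c1ccccc1`: 71.1 ug/mL
compound 2 `Fc1ccccc1/C=N/c1sc2c(c1-c1nc3ccccc3s1)CCCC2`: 319 ug/mL
compound 3 `O=[N+]([O-])c1ccc(/C=N/c2sc3c(c2-c2nc4ccccc4s2)CCCC3)cc1`: 316 ug/mL

In an ADME assay on cells (Rhabdomyosarcoma cell, Homo sapiens) for cytotoxicity, read by MTT assay, with a stated time of 72 h (a lower number here means that less compound is tolerated, a higher number that more compound is tolerated), compound 3 gives 316 ug/mL, level with compound 2 at 319 ug/mL. Exchanging 2-fluorophenyl for 4-nitrophenyl gave a 1.0-fold lower number from compound 2 to compound 3 (0.00 log units; within the scatter). Only compound 1 stands apart from the other two, with the lowest value of the three. Adding a nitro group gave a 4.4-fold higher number from compound 1 to compound 3 (0.65 log units; beyond the scatter), and fluoro in place of hydrogen on an aromatic carbon gave a 4.5-fold higher number from compound 1 to compound 2 (0.65 log units; beyond the scatter).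

Compound 4 `C(=C/c1ccccc1)\C=N\c1sc2c(c1-c1nc3ccccc3s1)CCCC2` differs from compound 3 as follows: 2-phenylethenyl in place of 4-nitrophenyl on a carbon with a double bond to nitrogen. In words, this is 2-phenylethenyl in place of 4-nitrophenyl on a carbon with a double bond to nitrogen. Within the data shown here, no measured step covers this exchange directly, and the effect of the added double bond is untested. The closest guide is a 4.4-fold higher number from compound 1 to compound 3 (0.65 log units; beyond the scatter), read in reverse, since the nitro group leaves. Compound 4 is therefore expected to fall part of the way back towards compound 1 at 71.1 ug/mL. In this assay a modest fall is expected, namely a 2.3-fold lower number from compound 3 to compound 4 (0.35 log units; beyond the scatter). For compound 4 the estimated value is 140 ug/mL, with an expected range of 55 ug/mL to 350 ug/mL.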

Compound 4, half-maximal cytotoxic concentration: 207 ug/mL
Compound 4: middle estimate off by 1.5-fold (0.17 log units), on the low side; low and high end bracket the measured number.
By their numbers in this assay, from the lowest: compound 1; then compounds 4, 3 and 2 (each within the scatter of the next).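

In this assay, compound 4 shows that a group with no fluoro or nitro substituent can also sit on this carbon with a double bond to nitrogen and give a number in the same range as the substituted phenyl compounds: the exchange gives a 1.5-fold lower number from compound 3 to compound 4 (0.18 log units; within the scatter) and, against the fluorinated compound, a 1.5-fold lower number from compound 2 to compound 4 (0.19 log units; within the scatter), both steps inside the scatter. Among these compounds, the 2-phenylethenyl group also separates from plain phenyl, with a 2.9-fold higher number from compound 1 to compound 4 (0.46 log units; beyond the scatter), so compound 1 is now the only one of the four that stands apart, and a substituent on the phenyl ring is no longer the only change seen to raise the number at this position. No measurement in hand bears on why these groups behave alike in this assay.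

The compounds shown leave open whether the double bond of 2-phenylethenyl matters, which a saturated 2-phenylethyl chain at the same carbon would test. They also leave open whether a phenyl ring carrying an amine or a carboxylic acid would group with compound 1 or with compounds 2, 3 and 4.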